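From Hydroxymethyl to Hydrogen on a Saturated Ring Carbon

The source may hold more compounds than are shown below. What is called first, only, known or untested is meant among the compounds shown, and "the series" means these compounds.

In a functional assay on PC-3 cells (Homo sapiens) for inhibition (a higher number here means a weaker inhibitor, a lower number a stronger inhibitor), compound 1 (`CCCCCCCCCCCCCCCCCCOC[C@H](COC(=O)O[C@@H]1[C@H](O)[C@@H](CO)[C@@H](O)[C@H](O)[C@@H]1O)OC`) gives 10000 nM, while compound 2 (`CCCCCCCCCCCCCCCCCCOC[C@H](COC(=O)O[C@@H]1[C@H](O)[C@H](CO)[C@@H](O)[C@H](O)[C@@H]1O)OC`) gives 2000 nM, the lower of the two numbers. Within the data shown here, the only measured step, a 5.0-fold lower number from compound 1 to compound 2 (0.70 log units; beyond the scatter), rests on (the fact that compounds 1 and 2 differ only in the configuration as drawn). Compound 3 (`CCCCCCCCCCCCCCCCCCOC[C@H](COC(=O)O[C@H]1[C@@H](O)[C@@H](O)[C@H](O)C[C@H]1O)OC`) has hydrogen in place of hydroxymethyl on a saturated ring carbon. Among the measured compounds shown here, no measured step removes that group, so the size of a 5.0-fold lower number from compound 1 to compound 2 (0.70 log units; beyond the scatter) is only a rough guide. A modest rise is expected, namely a 2.5-fold higher number from compound 2 to compound 3 (0.40 log units; beyond the scatter). For compound 3 the estimated value is 5000 nM, within a range of 1500 nM to 15000 nM.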

Compound 3, half-maximal inhibitory concentration: 7000 nM
Estimate against measurement, compound 3: 1.4-fold (0.15 log units) below, within the range that was stated.
By their numbers in this assay, from the lowest: compound 2; then compounds 3 and 1 (each within the scatter of the next).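

In this assay, hydrogen in place of hydroxymethyl on this saturated ring carbon gives two different readings: a 3.5-fold higher number from compound 2 to compound 3 (0.54 log units; beyond the scatter) but a 1.4-fold lower number from compound 1 to compound 3 (0.15 log units; within the scatter). The effect of removing the group therefore depends on how the hydroxymethyl is drawn at this carbon, with only the arrangement in compound 2 standing apart from the hydrogen compound 3, and this reading rests on one fact: the fact that compounds 1 and 2 differ only in the configuration as drawn. On these data alone, whether the oxygen of the hydroxymethyl matters, as a methyl group in its place could show, remains open. So does the outcome with an aminomethyl group or a carboxylic acid on this carbon.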